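The source may hold more compounds than are shown below. What is called first, only, known or untested is meant among the compounds shown, and "the series" means these compounds.

Measured so far: compound 1 `O=C(c1ccn2c1CSC2c1cccnc1)c1c[nH]c2cc(-c3ccc(F)cc3)ccc12`, which in a functional assay on the whole organism for inhibition, with Rattus norvegicus as the target (a higher number here means that more compound is needed for the effect, a lower number that less compound is needed), gives 6.4 mg/kg; compound 2 `CN(C)C(=O)Cn1cc(C(=O)c2ccn3c2CSC3c2cccnc2)c2ccc(-c3ccc(F)cc3)cc21`, which gives 0.12 mg/kg.

Among the compounds with values here, compound 2 holds the lower of the two numbers; the single step in hand, a 53-fold lower number from compound 1 to compound 2 (1.73 log units; beyond the scatter), shows that a group on the aromatic nitrogen can lower the dose markedly. Compound 3 `NNC(=O)n1cc(C(=O)c2ccn3c2CSC3c2cccnc2)c2ccc(-c3ccc(F)cc3)cc21` differs from compound 2 by aminocarbamoyl in place of (dimethylcarbamoyl)methyl on an aromatic nitrogen. Within the data shown here, no measured step covers the exchange of one such group for another, so the gain in a 53-fold lower number from compound 1 to compound 2 (1.73 log units; beyond the scatter) cannot simply be carried over, and part of it is expected to be lost. Compound 3 is estimated at 0.8 mg/kg, between 0.15 mg/kg and 5 mg/kg, a step of a 6.7-fold higher number from compound 2 to compound 3 (0.82 log units; beyond the scatter).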

Compound 3, dose for half-maximal effect: 0.57 mg/kg
Compound 3: the middle estimate sits 1.4-fold (0.15 log units) above what was measured; measured number inside the range.
By their numbers in this assay, from the lowest: compound 2; then compound 3; then compound 1.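

In this assay, aminocarbamoyl on the aromatic nitrogen also gives a lower number than hydrogen (an 11-fold lower number from compound 1 to compound 3 (1.05 log units; beyond the scatter)), so the drop at this position is not confined to (dimethylcarbamoyl)methyl. The two groups are not interchangeable, though (a 4.8-fold higher number from compound 2 to compound 3 (0.68 log units; beyond the scatter)), and the smaller aminocarbamoyl keeps only part of the drop seen with (dimethylcarbamoyl)methyl. No available evidence accounts for the difference between these groups.

Open, as far as these compounds go, is where a plain methyl, a carboxylic acid or an amine on a longer chain at this nitrogen would fall relative to these two groups.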